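Thiophen-2-yl to 3,5-dimethylphenyl: expected effect on growth inhibition

The compounds below may be only part of what the source reports. "The series", "measured", "known", "first", "only" and "open" are said of these compounds alone.

In a functional assay on DU-145 cells (Homo sapiens) for inhibition, read by trypan blue exclusion, with a stated time of 96 h (on this read-out higher numbers stand for weaker inhibition of growth and lower numbers for stronger inhibition of growth), compound 1 (`Cc1ccc(S(=O)(=O)/C(=C/c2ccc(O)c([N+](=O)[O-])c2)C(=O)c2ccc(Cl)cc2)cc1`) gives 25000 nM and compound 2 (`Cc1ccc(S(=O)(=O)/C(=C/c2cccs2)C(=O)c2ccc(Cl)cc2)cc1`) gives 25000 nM as its read-out, so compound 2 stands level with compound 1. Compound 3 (`Cc1ccc(S(=O)(=O)/C(=C/c2cc(C)cc(C)c2)C(=O)c2ccc(Cl)cc2)cc1`) changes the same place: 3,5-dimethylphenyl in place of thiophen-2-yl on a double-bonded chain carbon bound to a double-bonded chain carbon. Among the measured compounds shown here, one measured step bears on this place: no change at the digits printed from compound 1 to compound 2 (within the scatter) for the exchange of 4-hydroxy-3-nitrophenyl for thiophen-2-yl. For the measured compounds named here, that single step is thin support, and no measured compound carries 3,5-dimethylphenyl. In this assay no shift beyond the scatter and no direction is therefore expected. The estimated step is no change at the digits printed from compound 2 to compound 3 (within the scatter) on this basis. The expected value for compound 3 is 25000 nM (estimated range 8000 nM to 60000 nM).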

Compound 3, concentration for 50% growth inhibition: 1000 nM
Estimate against measurement, compound 3: 25-fold (1.40 log units) above; measured number below the stated range.
By their numbers in this assay, from the lowest: compound 3; then compounds 1 and 2 (each within the scatter of the next).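

In this assay, this place on a double-bonded chain carbon bound to a double-bonded chain carbon turns out to be sensitive to the group it carries: 3,5-dimethylphenyl gives a 25-fold lower number from compound 2 to compound 3 (1.40 log units; beyond the scatter) and also a 25-fold lower number from compound 1 to compound 3 (1.40 log units; beyond the scatter) in the same direction, a separation the earlier exchange did not show. Compound 1 also has a six-membered aromatic ring of carbon only at this place, so such a ring alone does not go with the lower number, and the comparison points to the substitution on the ring rather than to the ring itself. No measured evidence on the cause of this step is at hand.

Still open, on these data alone, is whether both methyl groups are needed, as a single methyl or an unsubstituted phenyl would show. Also open, as far as these compounds go, is whether 3,5-dimethoxyphenyl or 3,5-diethylphenyl would hold the lower number.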